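The source may hold more compounds than are shown below. What is called first, only, known or untested is meant among the compounds shown, and "the series" means these compounds.

The measured compounds in an assay on isolated protein for inhibition of Nicotinamide phosphoribosyltransferase (Homo sapiens), read by mass spectrometry, with stated times of 15 min and 30 min (a higher number here means a weaker inhibitor, a lower number a stronger inhibitor), are:

compound 1 `O=C(NCc1ccc(S(=O)(=O)c2cccc(C(F)(F)F)c2)cc1)N1Cc2ccncc2C1`, 8 nM
compound 2 `O=C(NCc1ccc(S(=O)(=O)c2cc(F)cc(F)c2)cc1)N1Cc2ccncc2C1`, 7.1 nM
compound 3 `O=C(NCc1ccc(S(=O)(=O)C2CCN(C3COC3)CC2)cc1)N1Cc2ccncc2C1`, 31 nM

Compound 3 stands at the highest number of the three in this assay; its nearest neighbour is compound 1 and its furthest is compound 2, both beyond the scatter. Compound 4 `CN1CCN(S(=O)(=O)c2ccc(CNC(=O)N3Cc4ccncc4C3)cc2)CC1` is not yet measured. It differs from compound 3 in one place: 4-methylpiperazin-1-yl in place of 1-(oxetan-3-yl)piperidin-4-yl on a sulfonyl sulfur.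

Among the measured compounds shown here, two measured steps bear on this change, since both replace an aromatic ring on the sulfonyl sulfur with a saturated ring carrying a nitrogen: a 3.9-fold higher number from compound 1 to compound 3 (0.59 log units; beyond the scatter) and a 4.4-fold higher number from compound 2 to compound 3 (0.64 log units; beyond the scatter). Both are modest losses. For the measured compounds named here, compound 4 keeps a saturated, nitrogen-containing ring on the sulfonyl sulfur, so the nearest precedent is compound 3 itself rather than the aryl compounds. Going by the values given here, no step between two saturated rings at this position has been measured, so the expectation rests on compound 3 alone and is wide. Compound 4 is therefore expected to stay close to compound 3 in this assay, with the step of a 1.3-fold higher number from compound 3 to compound 4 (0.11 log units; within the scatter) expected to lie within the scatter. The estimate for compound 4 is 40 nM, with a range of 15 nM to 110 nM.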

Compound 4, half-maximal inhibitory concentration: 38 nM
Estimate against measurement, compound 4: 1.1-fold (0.02 log units) above; low and high end bracket the measured number.
By their numbers in this assay, from the lowest: compounds 2 and 1 (each within the scatter of the next); then compounds 3 and 4 (each within the scatter of the next).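

In this assay the sulfonyl sulfur takes one saturated ring in place of another without a measurable shift: a 1.2-fold higher number from compound 3 to compound 4 (0.09 log units; within the scatter) even though 4-methylpiperazin-1-yl has fewer heavy atoms and lacks the four-membered ring of the group it replaces. The gap to the aryl compounds therefore recurs with a second saturated ring, as a 5.4-fold higher number from compound 2 to compound 4 (0.73 log units; beyond the scatter) and a 4.8-fold higher number from compound 1 to compound 4 (0.68 log units; beyond the scatter) both lie beyond the scatter, so it is not peculiar to compound 3. Nothing available accounts for this gap.

On these data alone, whether a cyclohexyl or tetrahydropyran-4-yl ring on the sulfonyl sulfur would group with the aryl compounds or with compound 3 and compound 4 stays open. The ring nitrogen therefore cannot yet be separated from the loss of the aromatic ring.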